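Swapping the Chain Amine on a Difluorophenyl Triazole

The source may hold more compounds than are shown below. What is called first, only, known or untested is meant among the compounds shown, and "the series" means these compounds.

Of the compounds shown here, three sharing one core have been measured in a functional assay on HT-29 cells (Homo sapiens) for cytotoxicity, read by MTT assay, with a stated time of 72 h; on this read-out lower numbers stand for stronger inhibition and higher numbers for weaker inhibition. Compound 1 `COc1cc2c(Oc3ccc(NC(=O)c4cn(-c5ccccc5C)nn4)cc3F)ccnc2cc1OCCCN1CCCCC1` gives 1340 nM. Compound 2 `COc1cc2c(Oc3ccc(NC(=O)c4cn(-c5ccccc5F)nn4)cc3F)ccnc2cc1OCCCN1CCCCC1` gives 290 nM. Compound 3 `COc1cc2c(Oc3ccc(NC(=O)c4cn(-c5ccc(F)c(F)c5)nn4)cc3F)ccnc2cc1OCCCN1CCCCC1` gives 210 nM. On these numbers compound 3 has the lowest value of the three, but the gap a 1.4-fold lower number from compound 2 to compound 3 (0.14 log units; within the scatter) lies within the scatter, so compounds 2 and 3 cannot be told apart; the steps of a 6.4-fold lower number from compound 1 to compound 3 (0.80 log units; beyond the scatter) and a 4.6-fold lower number from compound 1 to compound 2 (0.66 log units; beyond the scatter) stand beyond it.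

Compound 4 `COc1cc2c(Oc3ccc(NC(=O)c4cn(-c5ccc(F)c(F)c5)nn4)cc3F)ccnc2cc1OCCCN1CCN(C)CC1` differs from compound 3 at the far end of the chain: 4-methylpiperazin-1-yl in place of piperidin-1-yl on a saturated chain carbon, three bonds along the chain from an oxygen on an aromatic ring. For the measured compounds named here, none of the measured steps touches this part of the molecule; all three concern the aryl group on the triazole nitrogen, while the chain amine is the same in compounds 1, 2 and 3. Going by the values given here, there is thus no measured step that bears on this change, and no step beyond the scatter is expected, the estimated step being a 1.2-fold higher number from compound 3 to compound 4 (0.08 log units; within the scatter). Compound 4 is therefore expected to give about 250 nM, within a range of 80 nM to 800 nM.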

Compound 4, half-maximal inhibitory concentration: 430 nM
Compound 4: middle estimate off by 1.7-fold (0.24 log units), on the low side, and the stated range covers the measured number.
By their numbers in this assay, from the lowest: compounds 3, 2 and 4 (each within the scatter of the next, the first and the last beyond it); then compound 1.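

The chain amine now has a measured step of its own: in this assay, 4-methylpiperazin-1-yl in place of piperidin-1-yl gives a 2.0-fold higher number from compound 3 to compound 4 (0.31 log units; beyond the scatter) with the 3,4-difluorophenyl group held fixed, a modest step that stands beyond the scatter. For the compounds shown here, the earlier compounds differed only in the aryl group on the triazole nitrogen, so this is the first sign that the far end of the chain has a bearing on this read-out. Nothing measured here explains the step.

On these data alone, it remains open whether the step follows from the second ring nitrogen or from its methyl group, which piperazin-1-yl or morpholin-4-yl on the same chain could separate. As far as these compounds go, it is also open whether the step holds with another aryl group, such as the 2-fluorophenyl of compound 2, or with a shorter or longer chain.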